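The source may hold more compounds than are shown below. What is called first, only, known or untested is meant among the compounds shown, and "the series" means these compounds.

Compound 1 `O=C(Nc1cccc(-n2cc(-c3ccncc3)c(-c3ccc(Cl)c(O)c3)n2)c1)Nc1ccc(Cl)c(Cl)c1` and compound 2 `COc1cc(-c2nn(-c3cccc(NC(=O)Nc4ccc(Cl)c(C(F)(F)F)c4)c3)cc2-c2ccncc2)ccc1Cl` share a core and differ in two places at once. In a functional assay on SF-539 cells (Homo sapiens) for inhibition, read by sulforhodamine B assay, with a stated time of 48 h (a higher number here means a weaker inhibitor of growth, a lower number a stronger inhibitor of growth), compound 1 gives 1340 nM, and compound 2 gives 1650 nM; the two values lie within the usual scatter of each other. Compound 3 `O=C(Nc1cccc(-n2cc(-c3ccncc3)c(-c3ccc(Cl)c(O)c3)n2)c1)Nc1ccc(Cl)c(C(F)(F)F)c1` is compound 2 with one change: hydrogen in place of methyl on an oxygen on an aromatic ring, that is, methoxy to hydroxy. Among the compounds with values here, no measured pair shows this single change here, so for compound 3 the step of a 1.2-fold lower number from compound 2 to compound 3 (0.07 log units; within the scatter) is expected to stay within the scatter. Compound 3 is estimated at 1400 nM, in a range from 600 nM to 3500 nM.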

Compound 3, concentration for 50% growth inhibition: 782 nM
Compound 3: middle estimate off by 1.8-fold (0.25 log units), on the high side, and the stated range covers the measured number.
By their numbers in this assay, from the lowest: compounds 3, 1 and 2 (each within the scatter of the next, the first and the last beyond it).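

In this assay, methoxy to hydroxy gives a 2.1-fold lower number from compound 2 to compound 3 (0.32 log units; beyond the scatter), a modest step and the only single change shown at this position. Trifluoromethyl in place of chloro on an aromatic carbon, with the hydroxy kept, gives a 1.7-fold lower number from compound 1 to compound 3 (0.23 log units; within the scatter), so these two compounds cannot be told apart. Nothing measured here explains either result.

Still open, from the compounds shown here alone, is whether an amine in place of the hydroxy would hold this level of growth inhibition. Going by these compounds, it is also open whether the methoxy to hydroxy step holds with chloro in place of trifluoromethyl, as compound 1 has no methoxy partner here.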